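A few compounds are considered here, and "the series" means these few. Any claim that something is new, unique, unknown or untested is made for them only; others in the source may bear on it.

Measured in a functional assay on HepG2 cells (Homo sapiens) for inhibition, read by MTT assay, with a stated time of 72 h; on this read-out lower numbers stand for stronger inhibition and higher numbers for weaker inhibition:
- compound 1 `CCCCCc1ccc(NC(=O)C2CCN(C/C=C/c3ccccc3)CC2)cc1`: 2890 nM
- compound 2 `COc1ccc(NC(=O)C2CCN(C/C=C/c3ccccc3)CC2)cc1`: 88800 nM

Compound 2 holds the higher of the two numbers. Compound 3 `O=C(Nc1ccccn1)C1CCN(C/C=C/c2ccccc2)CC1` has pyridin-2-yl in place of 4-methoxyphenyl on an amide-type nitrogen. Going by the values given here, only one measured step bears on this, and only indirectly. The large step of a 31-fold higher number from compound 1 to compound 2 (1.49 log units; beyond the scatter) put methoxy in place of pentyl on an aromatic carbon. Among the compounds with values here, neither compound 2 nor compound 3 carries pentyl, so no step of that size is expected in this assay, and no clear direction is expected either. The expected step, within the scatter, is a 1.1-fold lower number from compound 2 to compound 3 (0.05 log units; within the scatter). The estimate for compound 3 is 80000 nM, with an expected range of 25000 nM to 250000 nM.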

Compound 3, half-maximal inhibitory concentration: 51100 nM
The estimate for compound 3 lay 1.6-fold (0.19 log units) above the measured number; the measured number falls inside the stated range.
By their numbers in this assay, from the lowest: compound 1; then compounds 3 and 2 (each within the scatter of the next).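

Replacing the whole group on the amide-type nitrogen, pyridin-2-yl in place of 4-methoxyphenyl, gives a 1.7-fold lower number from compound 2 to compound 3 (0.24 log units; within the scatter) in this assay. Unlike the change on the aromatic carbon, a 31-fold higher number from compound 1 to compound 2 (1.49 log units; beyond the scatter), this swap of an aromatic carbon ring for a ring with a hetero atom does not separate the two compounds. No measurement available here accounts for this result. As far as these compounds go, whether pentyl on the pyridin-2-yl ring would bring the number close to that of compound 1 remains open. So does the effect of an amine or a carboxylic acid on that ring.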